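This account rests on a few compounds, and the source may have more. Where it says the series, first, only, none or still open, it means among the compounds named here.

Compound 1 `CCCCCCCN(CCCCCCC)C(=O)Nc1ccc(C)cc1C` gives 0.26 ug/mL in an assay on isolated protein for inhibition of sterol O-acyltransferase 1 (Rattus norvegicus); a higher number here means a weaker inhibitor, a lower number a stronger inhibitor. Compound 2 `Cc1cc(C)c(NC(=O)N(Cc2ccccc2)Cc2ccccc2)c(C)c1` gives 1.34 ug/mL. Compound 3 `O=C(Nc1cc(Cl)cc(Cl)c1)N(Cc1ccccc1)Cc1ccccc1` gives 1.53 ug/mL.

Compound 3 carries the highest of the three numbers, although compound 2 sits within the scatter of it, and only compound 1 lies clearly lower. Compound 4 `Cc1ccc(NC(=O)N(Cc2ccccc2)Cc2ccccc2)cc1Cl` differs from compound 3 in one place: 3-chloro-4-methylphenyl in place of 3,5-dichlorophenyl on an amide-type nitrogen. Among the measured compounds shown here, the one measured step that bears on this, an exchange of the aryl group on the same nitrogen, is a 1.1-fold higher number from compound 2 to compound 3 (0.06 log units; within the scatter), which hardly moved the number. On that basis the expected step is a 1.2-fold lower number from compound 3 to compound 4 (0.07 log units; within the scatter), no change beyond the scatter. Compound 4 is therefore estimated at 1.3 ug/mL, with a likely range from 0.5 ug/mL to 3.5 ug/mL in this assay.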

Compound 4, half-maximal inhibitory concentration: 6.88 ug/mL
For compound 4 the middle estimate is 5.3-fold (0.72 log units) below the measured one, and the stated range ends below it.
By their numbers in this assay, from the lowest: compound 1; then compounds 2 and 3 (each within the scatter of the next); then compound 4.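

In this assay the aryl group on this amide-type nitrogen is not indifferent: the earlier exchange stayed within the scatter, but 3-chloro-4-methylphenyl brings a 4.5-fold higher number from compound 3 to compound 4 (0.65 log units; beyond the scatter) and a 5.1-fold higher number from compound 2 to compound 4 (0.71 log units; beyond the scatter) as well. Both the leaving 3,5-dichlorophenyl and the entering group have 8 heavy atoms, so that count alone does not follow the number here. Nothing available explains this rise. Going by these compounds, what an aryl group carrying an amine or a carboxylic acid would give stays open, as does whether this step would hold on the core of compound 1.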